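Lengthening the urea terminus of compound 1

A few compounds are considered here, and "the series" means these few. Any claim that something is new, unique, unknown or untested is made for them only; others in the source may bear on it.

compound 1, `COc1ncc(-c2ccc3nc(NC(=O)N(C)C)nn3c2)cc1NS(=O)(=O)c1ccc(F)cc1`: 1190 nM
compound 2, `CCN(CC)CCNC(=O)Nc1nc2ccc(-c3cnc(OC)c(NS(=O)(=O)c4ccc(C)cc4)c3)cn2n1`: 730 nM
compound 3, `CCN(CC)CCNC(=O)Nc1nc2ccc(-c3cnc(OC)c(NS(=O)(=O)c4ccc(F)cc4F)c3)cn2n1`: 980 nM

In a functional assay on A549 cells (Homo sapiens) for cytotoxicity, read by MTT assay, with a stated time of 72 h (a lower number here means a stronger inhibitor, a higher number a weaker inhibitor), compound 1 gives the highest of the three numbers, though its distance to compound 3 and to compound 2 stays within the scatter. Compound 4, `COc1ncc(-c2ccc3nc(NC(=O)NCCN(C)C)nn3c2)cc1NS(=O)(=O)c1ccc(F)cc1`, differs from compound 1 in one place: (2-(dimethylamino)ethyl)amino in place of dimethylamino on a carbonyl carbon. Among the compounds with values here, the only measured step, a 1.3-fold higher number from compound 2 to compound 3 (0.13 log units; within the scatter), alters the group on the sulfonyl sulfur and says nothing about the urea end; compounds 2 and 3 carry a longer chain on that carbonyl carbon and give numbers close to compound 1. Compound 4 is therefore expected to show no step beyond the scatter, a 1.2-fold lower number from compound 1 to compound 4 (0.08 log units; within the scatter). The estimated value of compound 4 is 1000 nM, with a range from 500 nM to 2000 nM.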

Compound 4, half-maximal inhibitory concentration: 800 nM
Compound 4: middle estimate off by 1.3-fold (0.10 log units), on the high side; low and high end bracket the measured number.
By their numbers in this assay, from the lowest: compounds 2, 4, 3 and 1 (each within the scatter of the next).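

In this assay, placing (2-(dimethylamino)ethyl)amino on the carbonyl carbon in place of dimethylamino gives a 1.5-fold lower number from compound 1 to compound 4 (0.17 log units; within the scatter), so this position accepts the longer chain without a step beyond the scatter. Within the data shown here, this is the first direct reading at the urea terminus, as the earlier step changed only the group on the sulfonyl sulfur. Nothing available explains this result. On these data alone, whether a morpholine, a carboxylic acid or a still longer chain on this carbonyl carbon would produce a step beyond the scatter remains open.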